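The source may report more compounds than this note shows. Statements on the series, on what has been measured and on what is new or still open speak of the compounds shown alone.

In a physicochemical assay for lipophilicity (on this read-out lower numbers stand for lower lipophilicity and higher numbers for higher lipophilicity), compound 3 (`CC1NC(NCC2COCCO2)=Nc2ccccc21`) gives -0.8, the lowest of the three numbers, against compound 1 (`CCCOCCNC1=Nc2ccccc2C(C)N1`) at 0.1 and compound 2 (`CC1NC(NCC2COc3ccccc3O2)=Nc2ccccc21`) at 1. Compound 4 (`CCCNC1=Nc2ccccc2C(C)N1`) carries ethyl in place of 1,4-dioxan-2-yl on a saturated chain carbon bound to an amine nitrogen. Among the measured compounds shown here, one measured step bears on this change: a number 0.90 log units lower from compound 1 to compound 3 (beyond the scatter), modest and beyond the scatter, with 1,4-dioxan-2-yl entering at the same place. Removing that group is therefore expected to move the number the other way in this assay, upward and by a similar size. The expected step is a number 0.80 log units higher from compound 3 to compound 4 (beyond the scatter). For compound 4 the estimated value is 0, with an expected range from -0.5 to 0.5.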

Compound 4, distribution coefficient: -0.8
Compound 4: the middle estimate sits 0.80 log units above what was measured; the measured number lies below the stated range.
By their numbers in this assay, from the lowest: compounds 3 and 4 (each within the scatter of the next); then compound 1; then compound 2.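

In this assay, ethyl in place of 1,4-dioxan-2-yl on this saturated chain carbon gives no change at the digits printed from compound 3 to compound 4 (within the scatter), so these two groups are not told apart on this read-out. Methyl in place of propoxy gives a number 0.90 log units lower from compound 1 to compound 4 (beyond the scatter), so a number at the level of compound 3 does not require 1,4-dioxan-2-yl. No measurement shown offers a reason for this.

On these data alone, whether a longer plain alkyl chain here would stay level with compound 4 or approach compound 1 remains open. So does the effect of an amine or a carboxylic acid at this place.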